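The source may report more compounds than this note shows. Statements on the series, on what has been measured and on what is new or still open speak of the compounds shown alone.

Three compounds have been measured in a functional assay on DLD-1 cells (Homo sapiens) for antiproliferative activity, read by CellTiter-Glo, with a stated time of 72 h; a higher number here means a weaker inhibitor, a lower number a stronger inhibitor:
Compound 1 `CC1CCN(C2CCN(S(=O)(=O)c3ccc(C(C)(C)C)cc3)CC2)CC1` gives > 5000 nM, a limit of the assay.
Compound 2 `CCc1ccc(S(=O)(=O)N2CCC(N3CCC(C)CC3)CC2)cc1` gives > 5000 nM, also a limit of the assay.
Compound 3 `COc1ccc(-c2ccc(S(=O)(=O)N3CCC(N4CCC(C)CC4)CC3)cc2)cc1` gives 263 nM.

Compound 2 thus stands at the limit of > 5000 nM in this assay, at which 2 of the 3 values shown sit, the same position as compound 1, and only compound 3 has a proper number. Compound 4 `CC1CCN(C2CCN(S(=O)(=O)c3cccnc3F)CC2)CC1` differs from compound 2 in one place: 2-fluoropyridin-3-yl in place of 4-ethylphenyl on a sulfonyl sulfur. Among the compounds with values here, two measured steps touch this position. The step of an at least 19-fold lower number from compound 2 to compound 3 (1.27 log units; beyond the scatter) came from a 4-methoxyphenyl entering, while a step that the two limits leave unreadable from compound 1 to compound 2 exchanged one alkyl for another. A 2-fluoropyridin-3-yl is not a 4-methoxyphenyl, so the gain of compound 3 in an at least 19-fold lower number from compound 2 to compound 3 (1.27 log units; beyond the scatter) is not expected to repeat, and the limit of compound 2 in > 5000 nM is the nearest guide. Compound 4 is therefore estimated to stay near that limit, around 8000 nM (range 2000 nM to 30000 nM), an expected step that the limit leaves unreadable from compound 2 to compound 4.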

Compound 4, half-maximal inhibitory concentration: > 5000 nM
Compound 4 ended at the assay's limit; the forecaster's own chance of this, stated with the estimate: 75%; the middle value does not contradict the limit.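

Compound 2 and compound 4 each give only a limit of the assay, so the step between them cannot be read: the limit of > 5000 nM in this assay, at which 3 of the 4 values shown sit. On these data alone, whether 2-fluoropyridin-3-yl and 4-ethylphenyl differ at all in this assay stays open.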